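Saturating the acid-bearing side chain of compound 1

This account rests on a few compounds, and the source may have more. Where it says the series, first, only, none or still open, it means among the compounds named here.

Compound 1 `O=C(O)/C=C/c1ccc(Cn2cccn2)cc1OCCc1ccc2ccccc2c1` is measured in an assay on CHO cells for displacement of a labelled ligand from prostaglandin E2 receptor EP2 subtype (Mus musculus), read by scintillation counting (on this read-out lower numbers stand for stronger inhibition and higher numbers for weaker inhibition), and gives 3300 nM. Among the numbers shown it stands highest of the two that are plain numbers; the nearest is compound 3 `O=C(O)/C=C/c1ccc(OCc2ccccc2)cc1OCCc1ccc2ccccc2c1`, which gives 1200 nM, a step of a 2.8-fold lower number from compound 1 to compound 3 (0.44 log units; beyond the scatter). Compound 2 `O=C(O)/C=C/c1ccc(Cn2ccnc2)cc1OCCc1ccc2ccccc2c1` gives > 10000 nM, which is a limit of the assay and not a number, namely (the limit of > 10000 nM in this assay, at which 1 of the 3 values shown sits). The step of an at least 3.0-fold higher number from compound 1 to compound 2 (0.48 log units; beyond the scatter) and the step of an at least 8.3-fold lower number from compound 2 to compound 3 (0.92 log units; beyond the scatter) both concern the same group.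

Compound 4 `O=C(O)CCCc1ccc(Cn2cccn2)cc1OCCc1ccc2ccccc2c1` differs from compound 1 in one place: 3-carboxypropyl in place of 2-carboxyethenyl on an aromatic carbon. None of the three measured steps touches this part of the molecule, since all of them vary another group while the acid-bearing chain stays the same, so they give no direction for this change. With nothing to point either way, the expectation for compound 4 in this assay is a step of a 1.2-fold higher number from compound 1 to compound 4 (0.08 log units; within the scatter), lying within the usual scatter of repeated measurements. The estimated value for compound 4 is therefore 4000 nM, expected between 1500 nM and 10000 nM.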

Compound 4, inhibition constant: 1800 nM
Estimate against measurement, compound 4: 2.2-fold (0.35 log units) above, and the stated range covers the measured number.
By their numbers in this assay, from the lowest: compounds 3, 4 and 1 (each within the scatter of the next, the first and the last beyond it). At a limit, above all of these: compound 2.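

In this assay, swapping 2-carboxyethenyl for the saturated 3-carboxypropyl chain gives a 1.8-fold lower number from compound 1 to compound 4 (0.26 log units; within the scatter), so this change does not separate the two compounds. Within the data shown here, this is the first look at the acid-bearing chain on this aromatic carbon, ortho to a large group and para to the (1H-pyrazol-1-yl)methyl group: here the chain can lose its double bond and still read the same within the scatter. Nothing in the data shown accounts for this result.

Every chain shown ends in a carboxylic acid, so the compounds leave open how an ester, an amide or a still longer chain would read at this position. They also leave open whether the same chain swap would give a similar result on compound 3, which carries benzyloxy in place of the (1H-pyrazol-1-yl)methyl group.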